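Swapping a pyrazole for a two-ring group

The compounds below may be only part of what the source reports. "The series", "measured", "known", "first", "only" and "open" are said of these compounds alone.

Values measured in a physicochemical assay for solubility, in phosphate buffer, at pH 7.4; on this read-out lower numbers stand for lower solubility and higher numbers for higher solubility:
- Compound 1 `CC(=O)N[C@@H]1CCC[C@H](C(=O)Nc2cc(-c3cnc(C)n3C(C)C)ccn2)C1`: 660000 nM
- Compound 2 `CC(=O)N[C@@H]1CCC[C@H](C(=O)Nc2cc(-c3cnn(C)c3C)c(Cl)cn2)C1`: 960000 nM
- Compound 3 `CC(=O)N[C@@H]1CCC[C@H](C(=O)Nc2cc(-c3cnc4ccccn34)c(Cl)cn2)C1`: 120000 nM

Compound 2, at 960000 nM, and compound 1, at 660000 nM, lie within the usual scatter of each other, and together they form the top of this small set. Compound 4 `CC(=O)N[C@@H]1CCC[C@H](C(=O)Nc2cc(-c3nnn4ccccc34)c(Cl)cn2)C1` has not yet been measured. The change from compound 2 is a group of 9 heavy atoms (6 carbon, 3 nitrogen; one five-membered aromatic ring with 3 hetero atoms, one six-membered aromatic ring with 1 hetero atom) in place of a group of 7 heavy atoms (5 carbon, 2 nitrogen; one five-membered aromatic ring with 2 hetero atoms), on an aromatic carbon. The 1,5-dimethyl-1H-pyrazol-4-yl group leaves, and the new group sits ortho to a chloro group, opposite the ring nitrogen.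

Within the data shown here, only one measured step bears on this: an 8.0-fold lower number from compound 2 to compound 3 (0.90 log units; beyond the scatter). Compound 3, at 120000 nM, also carries a group with a five-membered and a six-membered aromatic ring at this place, though its five-membered ring holds fewer hetero atoms. With a single precedent the expectation is loose, but a drop of similar size in this assay seems most likely. The estimate is a 6.4-fold lower number from compound 2 to compound 4 (0.81 log units; beyond the scatter). For compound 4 the expected value is 150000 nM, with an estimated range from 50000 nM to 450000 nM.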

Compound 4, solubility: 530000 nM
Beside the measured number, compound 4's estimate is 3.5-fold (0.55 log units) below it, and the stated range ends below it.
By their numbers in this assay, from the lowest: compound 3; then compounds 4, 1 and 2 (each within the scatter of the next).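

In this assay, a two-ring group on this aromatic carbon need not shift the result measurably, since the swap of the pyrazole appears as a 1.8-fold lower number from compound 2 to compound 4 (0.26 log units; within the scatter) and so cannot be told apart from no change. Two-ring groups of equal heavy-atom count also do not behave alike here: the group with one more nitrogen and one fewer carbon gives a 4.4-fold higher number from compound 3 to compound 4 (0.65 log units; beyond the scatter), so the earlier drop cannot be read as following from the second ring alone. Nothing measured here explains why these two groups differ.

Still open, going by these compounds, is how this position would respond to a two-ring group carrying a morpholine or a carboxylic acid on its six-membered ring. The role of the chloro group is also unsettled, as compound 1 lacks it but differs from the others in more than one place.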